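A few compounds are considered here, and "the series" means these few. Any claim that something is new, unique, unknown or untested is made for them only; others in the source may bear on it.

Measured in an assay on LtK cells with ATP-sensitive inward rectifier potassium channel 11 (Homo sapiens) as the target; on this read-out lower numbers stand for an effect already at smaller amounts and higher numbers for an effect only at larger amounts of compound:
compound 1 `CCC(CC)C(=O)Nc1c(C(O)(C(F)(F)F)C(F)(F)F)ccc2ccccc12`: 4340 nM
compound 2 `COCC(=O)Nc1c(C(O)(C(F)(F)F)C(F)(F)F)ccc2ccccc12`: 213 nM
compound 3 `O=C(Nc1c(C(O)(C(F)(F)F)C(F)(F)F)ccc2ccccc12)c1cccc(Cl)c1`: 98 nM

Compound 3 gives the lowest number of the three in this assay, and its gaps to both other compounds lie beyond the scatter: the step of a 2.2-fold lower number from compound 2 to compound 3 (0.34 log units; beyond the scatter) is modest, the step of a 44-fold lower number from compound 1 to compound 3 (1.65 log units; beyond the scatter) large. Compound 4 `O=C(Nc1c(C(O)(C(F)(F)F)C(F)(F)F)ccc2ccccc12)c1cccc(Br)c1` differs from compound 3 only by bromo in place of chloro on an aromatic carbon. For the measured compounds named here, no measured step bears directly on such an exchange; every step so far replaces the whole group on the carbonyl carbon, and those steps were large or modest. A swap of one halogen for another on an aromatic carbon is a far smaller change than any of them, so the expected step of a 1.1-fold lower number from compound 3 to compound 4 (0.04 log units; within the scatter) in this assay is none beyond the scatter. Compound 4 is therefore estimated at 90 nM with a range of 40 nM to 200 nM.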

Compound 4, half-maximal effective concentration: 80 nM
Beside the measured number, compound 4's estimate is 1.1-fold (0.05 log units) above it, within the range that was stated.
By their numbers in this assay, from the lowest: compounds 4 and 3 (each within the scatter of the next); then compound 2; then compound 1.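

In this assay, the halogen on this aromatic carbon, meta to a large group, passes from chloro to bromo with no shift beyond the scatter (a 1.2-fold lower number from compound 3 to compound 4 (0.09 log units; within the scatter)). The 3-bromophenyl group also holds the gains of the 3-chlorophenyl group over the other carbonyl substituents (a 2.7-fold lower number from compound 2 to compound 4 (0.43 log units; beyond the scatter); a 54-fold lower number from compound 1 to compound 4 (1.73 log units; beyond the scatter)). Among these compounds, then, the differences follow the whole group on the carbonyl carbon, not this halogen.

From the compounds shown here alone, whether fluoro, methoxy, nitrile or an amine would fit at this place remains open. Nothing available explains why chloro and bromo read alike here.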